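Lipophilicity notes: replacing the terminal phenyl of compound 1

The compounds below may be only part of what the source reports. "The series", "measured", "known", "first", "only" and "open" are said of these compounds alone.

Measured so far:
compound 1 `CN(Cc1ccc2nccn2c1)c1nnc(-c2ccc(-c3ccccc3)cc2)o1` — 3.9
compound 2 `Cc1ncccc1-c1ccc(-c2nnc(N(C)Cc3ccc4nccn4c3)o2)cc1` — 3.1

In a physicochemical assay for lipophilicity, at pH 7.4 (a lower number here means a more polar compound, a higher number a more lipophilic compound), compound 1 gives 3.9 and stands highest of the two numbers measured, with compound 2 nearest. Among the compounds with values here, the one measured step, a number 0.80 log units lower from compound 1 to compound 2 (beyond the scatter), is the only comparison that bears on the new compound 3 `Cc1nn(C)c(C)c1-c1ccc(-c2nnc(N(C)Cc3ccc4nccn4c3)o2)cc1`. Compound 3 differs from compound 1 by 1,3,5-trimethyl-1H-pyrazol-4-yl in place of phenyl on an aromatic carbon. That step exchanges the same phenyl for a ring bearing two nitrogen atoms, so a downward move of a similar order is expected in this assay, roughly a number 0.70 log units lower from compound 1 to compound 3 (beyond the scatter). Compound 3 is therefore estimated at 3.2, within 2.6 to 3.8.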

Compound 3, distribution coefficient: 3.1
Estimate against measurement, compound 3: 0.10 log units above, and the stated range covers the measured number.
By their numbers in this assay, from the lowest: compounds 2 and 3 (each within the scatter of the next); then compound 1.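

In this assay, a second replacement of the terminal phenyl gives a number 0.80 log units lower from compound 1 to compound 3 (beyond the scatter), so the lower number at this position is no longer tied to 2-methylpyridin-3-yl alone. The five-membered 1,3,5-trimethyl-1H-pyrazol-4-yl and the six-membered 2-methylpyridin-3-yl are not separated here, with no change at the digits printed from compound 2 to compound 3 (within the scatter). Nothing available explains the shift from phenyl.

Open, as far as these compounds go, is what the methyl groups contribute, which an unsubstituted 1H-pyrazol-4-yl would address. Also open, from the compounds shown here alone, is how morpholine or a carboxylic acid at this place would read in this assay.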